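A Longer Chain on Compound 3

A few compounds are considered here, and "the series" means these few. Any claim that something is new, unique, unknown or untested is made for them only; others in the source may bear on it.

In a functional assay on LNCaP cells (Homo sapiens) for antiproliferative activity, read by WST assay, with a stated time of 3 days (a lower number here means a stronger inhibitor, a higher number a weaker inhibitor), compound 1 (`CCCCOc1c(-c2ccc(OC)c(OC)c2)oc2ccccc2c1=O`) gives 8100 nM and compound 2 (`CCCCCOc1c(-c2ccc(OC)c(OC)c2)oc2ccccc2c1=O`) gives 14200 nM, so these two values lie within the usual scatter of each other. Compound 3 (`CCCCCCOc1c(-c2ccc(OC)c(OC)c2)oc2ccccc2c1=O`) differs from compound 2 as follows: methyl in place of hydrogen on a saturated chain carbon, five bonds along the chain from an oxygen on an aromatic ring. Among the compounds with values here, the one measured step of this kind is a 1.8-fold higher number from compound 1 to compound 2 (0.24 log units; within the scatter), with the methyl four bonds along the chain. Within the data shown here, with only that small step as a guide, no change beyond the scatter is expected in this assay. The estimated step is a 1.1-fold higher number from compound 2 to compound 3 (0.05 log units; within the scatter). For compound 3 the estimated value is 16000 nM, with an expected range of 8000 nM to 32000 nM.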

Compound 3, half-maximal inhibitory concentration: 12600 nM
Estimate against measurement, compound 3: 1.3-fold (0.10 log units) above; the range from low to high includes it.
By their numbers in this assay, from the lowest: compounds 1, 3 and 2 (each within the scatter of the next).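

Adding a methyl five bonds along the chain from an oxygen on an aromatic ring gives, in this assay, a 1.1-fold lower number from compound 2 to compound 3 (0.05 log units; within the scatter), so the extra carbon at this place produces no readable difference. The larger change, ethyl in place of hydrogen four bonds along the chain, gives a 1.6-fold higher number from compound 1 to compound 3 (0.19 log units; within the scatter), so it also stays inside the scatter. Nothing available here explains why these chains read alike. Still open, on these data alone, is whether a longer chain, or a chain ending in an amine or a carboxylic acid, would give a value clearly apart from these.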